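A few compounds are considered here, and "the series" means these few. Any claim that something is new, unique, unknown or untested is made for them only; others in the source may bear on it.

Measured so far:
Compound 1 `Cc1cc2c(cc1Cl)NC(=O)C2(NC(=O)CN1CCN(C)CC1)c1cccc(Cl)c1` gives 1180 nM in an in vitro functional assay on CHO-CREluc cells for antagonist activity at growth hormone secretagogue receptor type 1 (Homo sapiens), read by a luciferase reporter, with a stated time of 4 h; a lower number here means a stronger inhibitor, a higher number a weaker inhibitor.
Compound 2 `Cc1cc2c(cc1Cl)NC(=O)C2(NC(=O)CN1CCN(c2ccncc2)CC1)c1ccc(Cl)cc1` reaches only the limit > 10000 nM in this assay.
Compound 3 `Cc1cc2c(cc1Cl)NC(=O)C2(NC(=O)CN1CCNCC1)c1ccc(Cl)cc1` likewise reaches only the limit > 10000 nM in this assay.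

Compound 3 thus stands at the limit, not at a number; the limit of > 10000 nM in this assay, at which 2 of the 3 values shown sit, is where two of the three values sit. Within the data shown here, the one measured step, a step that the two limits leave unreadable from compound 2 to compound 3, cannot be sized.

Compound 4 `CCN1CCN(CC(=O)NC2(c3ccc(Cl)cc3)C(=O)Nc3cc(Cl)c(C)cc32)CC1` differs from compound 3 by ethyl in place of hydrogen on an amine nitrogen in a ring. Among the measured compounds shown here, no measured step covers this change. For the measured compounds named here, compound 1, which carries methyl on that ring nitrogen but another chloro substitution on the pendant phenyl, gives a number while compound 3 gives a limit; no step is drawn between them. The step of an at least 1.6-fold lower number from compound 3 to compound 4 (0.22 log units; that floor lies within the scatter) is therefore expected to stay small. Compound 4 is estimated at 6000 nM (range 1000 nM to 30000 nM), most likely again a limit.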

Compound 4, half-maximal inhibitory concentration: 129 nM
Compound 4: the middle estimate sits 47-fold (1.67 log units) above what was measured; the whole stated range lies above it.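

Ethyl on the amine nitrogen in the ring turns a compound at the limit into a measurable antagonist in this assay, with an at least 77-fold lower number from compound 3 to compound 4 (1.88 log units; beyond the scatter). Ethyl in place of pyridin-4-yl at the same nitrogen gives an at least 77-fold lower number from compound 2 to compound 4 (1.88 log units; beyond the scatter), so the group on this nitrogen has a large effect on the read-out. Compound 2 and compound 3 both stand at a limit, so each step gives only a floor, not a size: the limit of > 10000 nM in this assay, at which 2 of the 4 values shown sit.

From the compounds shown here alone, what a propyl or cyclopropyl group on this nitrogen would give stays open. Methyl there appears only in compound 1, which differs from compound 4 in a second place, so no comparison of methyl with ethyl can be read.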